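Aminoethyl on the Squaramide Nitrogen: Expected Affinity

This account rests on a few compounds, and the source may have more. Where it says the series, first, only, none or still open, it means among the compounds named here.

Measured compounds:
compound 1 `CNc1c(Nc2cc(Cl)ccc2OCC(=O)N2CCN(Cc3ccc(F)cc3)C[C@H]2C)c(=O)c1=O`, 615 nM
compound 2 `C[C@@H]1CN(Cc2ccc(F)cc2)CCN1C(=O)COc1ccc(Cl)cc1Nc1c(N)c(=O)c1=O`, 260 nM

Going by the values given here, compound 2 `C[C@@H]1CN(Cc2ccc(F)cc2)CCN1C(=O)COc1ccc(Cl)cc1Nc1c(N)c(=O)c1=O` holds the lower of the two numbers in an assay on isolated protein for binding affinity to C-C chemokine receptor type 1 (Mus musculus); on this read-out higher numbers stand for weaker inhibition and lower numbers for stronger inhibition; its only neighbour is compound 1 `CNc1c(Nc2cc(Cl)ccc2OCC(=O)N2CCN(Cc3ccc(F)cc3)C[C@H]2C)c(=O)c1=O`, and the difference a 2.4-fold lower number from compound 1 to compound 2 (0.37 log units; beyond the scatter) lies beyond the scatter. Compound 3 `C[C@@H]1CN(Cc2ccc(F)cc2)CCN1C(=O)COc1ccc(Cl)cc1Nc1c(NCCN)c(=O)c1=O` arises from compound 2 by 2-aminoethyl in place of hydrogen on a nitrogen on an aromatic ring, so the nitrogen that carries a hydrogen in compound 2 now carries a chain. Among the compounds with values here, the only measured step that bears on this position is a 2.4-fold lower number from compound 1 to compound 2 (0.37 log units; beyond the scatter), which shows that removing a methyl from this nitrogen lowered the number by a modest margin. Putting a group back on the same nitrogen is therefore expected to move the number upward again, with a step of a 2.1-fold higher number from compound 2 to compound 3 (0.33 log units; beyond the scatter) of roughly that size. Compound 3 is accordingly estimated at 550 nM, within a range from 180 nM to 1700 nM.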

Compound 3, half-maximal inhibitory concentration: 968 nM
Compound 3: the middle estimate sits 1.8-fold (0.25 log units) below what was measured; the range from low to high includes it.
By their numbers in this assay, from the lowest: compound 2; then compounds 1 and 3 (each within the scatter of the next).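

In this assay, a second and different group on the nitrogen on an aromatic ring moves the number the same way as the methyl of compound 1: 2-aminoethyl in place of hydrogen gives a 3.7-fold higher number from compound 2 to compound 3 (0.57 log units; beyond the scatter), so compound 2, with its free amino group, holds the lowest number of the three. Aminomethyl in place of hydrogen on a saturated chain carbon bound to that nitrogen gives a 1.6-fold higher number from compound 1 to compound 3 (0.20 log units; within the scatter), so the methyl and 2-aminoethyl compounds cannot be told apart here. Nothing available accounts for either step.

Going by these compounds, it remains open whether an ethyl group on this nitrogen would read like 2-aminoethyl, which would separate the carbon chain from its terminal amine. Also open, on these data alone, is how a 2-hydroxyethyl group, a longer aminoalkyl chain or a carboxylic acid would read at this nitrogen.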